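Swapping Methoxy for Chloro on the Phenyl Ring

The source may hold more compounds than are shown below. What is called first, only, known or untested is meant among the compounds shown, and "the series" means these compounds.

Compound 3 `COc1ccc(-c2cn(/N=C/c3cc4ccccc4nc3Cl)c(N)n2)cc1` gives 31800 nM in a functional assay on HCT-116 cells (Homo sapiens) for cytotoxicity, read by MTT assay, with a stated time of 48 h (on this read-out higher numbers stand for weaker inhibition and lower numbers for stronger inhibition), the highest of the two numbers recorded there. Its nearest neighbour is compound 1 `Nc1nc(-c2ccccc2)cn1/N=C/c1cc2ccccc2nc1Cl`, which gives 6920 nM in this assay; that gap is a 4.6-fold higher number from compound 1 to compound 3 (0.66 log units; beyond the scatter). Compound 2 `Cc1ccc(-c2cn(/N=C/c3cc4ccccc4nc3Cl)c(N)n2)cc1` gives only > 50000 nM, a limit of the assay rather than a number (the limit of > 50000 nM in this assay, at which 1 of the 3 values shown sits). Compound 4 `Nc1nc(-c2ccc(Cl)cc2)cn1/N=C/c1cc2ccccc2nc1Cl` differs from compound 3 by chloro in place of methoxy on an aromatic carbon. Among the measured compounds shown here, no measured step puts chloro in place of methoxy, so the guides are a 4.6-fold higher number from compound 1 to compound 3 (0.66 log units; beyond the scatter) and an at least 7.2-fold higher number from compound 1 to compound 2 (0.85 log units; beyond the scatter), both of which raised the number when a group was added on that aromatic carbon. Chloro is a further group on the same carbon, so the step of a 1.6-fold lower number from compound 3 to compound 4 (0.20 log units; within the scatter) is expected to stay within the scatter. Compound 4 is therefore estimated at about 20000 nM in this assay, ranging from 6000 nM to 60000 nM.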

Compound 4, half-maximal inhibitory concentration: > 50000 nM
Compound 4: no number, only a limit (the forecaster's own chance of this, stated with the estimate: 25%); at least 2.5-fold (0.39 log units) between middle value and limit.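

Compound 4 gives a limit of the assay rather than a number, so the change from 4-methoxyphenyl to 4-chlorophenyl can only be stated as an at least 1.5-fold higher number from compound 3 to compound 4 (0.19 log units; that floor lies within the scatter). Against hydrogen on the same carbon, chloro gives an at least 7.2-fold higher number from compound 1 to compound 4 (0.85 log units; beyond the scatter), so all three groups shown there, in compound 2, compound 3 and compound 4, raise the number over compound 1. The step between compound 2 and compound 4 cannot be read, as both are limits: the limit of > 50000 nM in this assay, at which 2 of the 4 values shown sit.

On these data alone, whether every group on this carbon raises the number stays open. An amine or a carboxylic acid there could test this.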